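Para Substituent Swap: Fluoro to Chloro on the Benzyl Ether

This account rests on a few compounds, and the source may have more. Where it says the series, first, only, none or still open, it means among the compounds named here.

Measured compounds:
Compound 1 `Cc1ccc(COc2cc([N+](=O)[O-])ccc2NS(C)(=O)=O)cc1`, 1750 nM
Compound 2 `CC(C)c1ccc(COc2cc([N+](=O)[O-])ccc2NS(C)(=O)=O)cc1`, 7450 nM
Compound 3 `CS(=O)(=O)Nc1ccc([N+](=O)[O-])cc1OCc1ccc(F)cc1`, 580 nM

In an assay on SK-BR-3 cells for inhibition of Aromatase (Homo sapiens) (a higher number here means a weaker inhibitor, a lower number a stronger inhibitor), compound 3 stands lowest of the three: compound 1 is nearest and compound 2 furthest. Compound 4 `CS(=O)(=O)Nc1ccc([N+](=O)[O-])cc1OCc1ccc(Cl)cc1` carries the change (chloro in place of fluoro on an aromatic carbon), read one bond further out as 4-fluorophenyl to 4-chlorophenyl. For the measured compounds named here, no direct measurement of that swap exists here; the steps that bear on it are a 4.3-fold higher number from compound 1 to compound 2 (0.63 log units; beyond the scatter), a 3.0-fold lower number from compound 1 to compound 3 (0.48 log units; beyond the scatter) and a 13-fold lower number from compound 2 to compound 3 (1.11 log units; beyond the scatter), which show the larger groups at this position giving the higher numbers. Chloro, larger than fluoro, is therefore expected to move this assay in the weaker direction by a modest step, a 2.1-fold higher number from compound 3 to compound 4 (0.32 log units; beyond the scatter). Compound 4 is estimated at 1200 nM, within 500 nM to 3000 nM.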

Compound 4, half-maximal inhibitory concentration: 290 nM
The estimate for compound 4 lay 4.1-fold (0.62 log units) above the measured number; the whole stated range lies above it.
By their numbers in this assay, from the lowest: compounds 4 and 3 (each within the scatter of the next); then compound 1; then compound 2.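

In this assay the step of a 2.0-fold lower number from compound 3 to compound 4 (0.30 log units; within the scatter) leaves the two halogens unseparated at this position, so the rise seen from methyl to isopropyl does not carry over from fluoro to chloro. Chloro also stands clear of both alkyl groups, with a 6.0-fold lower number from compound 1 to compound 4 (0.78 log units; beyond the scatter) and a 26-fold lower number from compound 2 to compound 4 (1.41 log units; beyond the scatter) at the same place, so among these four compounds both halogens give lower numbers than both alkyl groups.

Nothing available here explains this difference. On these data alone, it remains open whether bromo, methoxy or an amine at this position would read like the halogens or like the alkyl groups.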